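A few compounds are considered here, and "the series" means these few. Any claim that something is new, unique, unknown or untested is made for them only; others in the source may bear on it.

Measured in a functional assay on A549 cells (Homo sapiens) for inhibition, read by MTT assay, with a stated time of 48 h, tested at 10 uM; a higher number here means more inhibition of growth at the concentration tested, a lower number less inhibition of growth:

compound 1 `C#CCOc1ccc(/C=C/C(=O)c2ccc(Br)cc2)cc1` — 34%
compound 2 `C#CCOc1ccc(/C=C/C(=O)c2ccc([N+](=O)[O-])cc2)cc1` — 33%
compound 3 `O=C(/C=C/c1ccc(OCc2cn(Cc3ccccc3Br)nn2)cc1)c1ccc(Br)cc1` — 44%

Compound 3 gives the highest of the three numbers in this assay. Compound 1 lies within the scatter of it, so no order between the two can be read; only compound 2 stands beyond the scatter below compound 3.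

Compound 4 `O=C(/C=C/c1ccc(OCc2cn(Cc3cccc(F)c3)nn2)cc1)c1ccc(Br)cc1` differs from compound 3 in one place: 3-fluorophenyl in place of 2-bromophenyl on a saturated chain carbon bound to an aromatic nitrogen. Among the compounds with values here, the only measured step, a number 1 percentage points lower from compound 1 to compound 2 (within the scatter), concerns a different part of the shared core and is within the scatter; no measured pair varies the group on the saturated chain carbon bound to the aromatic nitrogen. Within the data shown here, there is therefore no step in the data that bears directly on this change, and nothing that points to a shift in either direction in this assay beyond the scatter.

Compound 4 is accordingly expected to land near compound 3, at an estimated 42% with a range of 28% to 56%. The expected step is a number 2 percentage points lower from compound 3 to compound 4 (within the scatter).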

Compound 4, percent growth inhibition at one concentration: 37%
Estimate against measurement, compound 4: 5 percentage points above; the measured number falls inside the stated range.
By their numbers in this assay, from the lowest: compounds 2, 1, 4 and 3 (each within the scatter of the next, the first and the last beyond it).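

Within the data shown here, this is the first measured change at the group on a saturated chain carbon bound to an aromatic nitrogen: in this assay the exchange gives a number 7 percentage points lower from compound 3 to compound 4 (within the scatter) and so shows that replacing 2-bromophenyl with 3-fluorophenyl, both of 7 heavy atoms, leaves no readable difference at this position. The exchange alters both the halogen and its place on the phenyl group, and the result holds only for this pair. Nothing at hand offers an explanation of the step or links it to a property of either group.

The compounds shown do not separate the effect of the halogen from that of its place. They also leave open whether a different group here, such as an unsubstituted benzyl, an amine or a carboxylic acid, would move the number beyond the scatter.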